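Chain-extended acid on the shared core

This account rests on a few compounds, and the source may have more. Where it says the series, first, only, none or still open, it means among the compounds named here.

Compound 1 `O=C(O)CCCCOc1ccc2c(=O)c(-c3ccc(O)cc3)coc2c1` gives the lower of the two numbers in an assay (Cricetulus griseus) for inhibition of aldehyde dehydrogenase, mitochondrial (Homo sapiens) (on this read-out lower numbers stand for stronger inhibition and higher numbers for weaker inhibition), at 100 nM; compound 2 `CCCCCCC(Oc1ccc2c(=O)c(-c3ccc(O)cc3)coc2c1)C(=O)OCC` lies far higher, at 7200 nM. Compound 3 `O=C(O)CCCCCCCCCOc1ccc2c(=O)c(-c3ccc(O)cc3)coc2c1` has not yet been measured in this assay. It differs from compound 1 by 5-carboxypentyl in place of carboxy on a saturated chain carbon, four bonds along the chain from an oxygen on an aromatic ring. Within the data shown here, no measured pair shows this change, so its direction is not known from the data; a modest weakening is expected, with the step estimated at a 2.5-fold higher number from compound 1 to compound 3 (0.40 log units; beyond the scatter). On that basis compound 3 is expected to give 250 nM, within a range from 60 nM to 1000 nM.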

Compound 3, half-maximal inhibitory concentration: 50 nM
Estimate against measurement, compound 3: 5.0-fold (0.70 log units) above, and the stated range ends above it.
By their numbers in this assay, from the lowest: compounds 3 and 1 (each within the scatter of the next); then compound 2.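

In this assay, 5-carboxypentyl in place of carboxy at this saturated chain carbon gives a 2.0-fold lower number from compound 1 to compound 3 (0.30 log units; within the scatter). The position therefore accepts this much longer acid-bearing chain, and the number stays level with that of the shorter chain. Nothing available bears on why the longer chain is accepted.

Still open, as far as these compounds go, is whether chains of intermediate length, or a still longer chain, stay at this level. Also open, from the compounds shown here alone, is whether a primary amide or an amine at the chain end can replace the carboxylic acid.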